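The source may report more compounds than this note shows. Statements on the series, on what has been measured and on what is new or still open speak of the compounds shown alone.

Of the compounds shown here, two on the shared core have numbers so far in a functional assay on K562 cells (Homo sapiens) for inhibition, read by trypan blue exclusion, with a stated time of 72 h; on this read-out higher numbers stand for weaker inhibition and lower numbers for stronger inhibition. Compound 1 `Cn1c(=O)c(S(=O)(=O)c2ccc(Cl)cc2Cl)cc2cnc(Nc3ccc4[nH]ccc4c3)nc21` gives 1000 nM, and compound 2 `COc1ccc(S(=O)(=O)c2cc3cnc(Nc4ccc5[nH]ccc5c4)nc3n(C)c2=O)cc1` gives 300 nM, the lower of the two numbers. Among the measured compounds shown here, the only measured step, a 3.3-fold lower number from compound 1 to compound 2 (0.52 log units; beyond the scatter), puts 4-methoxyphenyl in place of 2,4-dichlorophenyl on a sulfonyl sulfur and is modest. Next comes compound 3 `Cn1c(=O)c(C(=O)Nc2ccc(F)cc2)cc2cnc(Nc3ccc4[nH]ccc4c3)nc21`, with (4-fluorophenyl)carbamoyl in place of (4-methoxyphenyl)sulfonyl on an aromatic carbon. For the measured compounds named here, no measured step covers a change of this kind, so the step to compound 2 from compound 1 offers only a rough guide to size. No clear direction can be drawn from it, and no shift beyond the scatter is expected in this assay. The expected step is a 1.3-fold higher number from compound 2 to compound 3 (0.12 log units; within the scatter). The estimated value for compound 3 is 400 nM, with an expected range of 100 nM to 1500 nM.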

Compound 3, half-maximal inhibitory concentration: 5000 nM
Beside the measured number, compound 3's estimate is 13-fold (1.10 log units) below it; the whole stated range lies below it.
By their numbers in this assay, from the lowest: compound 2; then compound 1; then compound 3.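

At this aromatic carbon, a 17-fold higher number from compound 2 to compound 3 (1.22 log units; beyond the scatter) in this assay is a far larger move than a 3.3-fold lower number from compound 1 to compound 2 (0.52 log units; beyond the scatter) on the aryl group of the sulfonyl alone. (2,4-Dichlorophenyl)sulfonyl also gives a lower number than (4-fluorophenyl)carbamoyl, as a 5.0-fold higher number from compound 1 to compound 3 (0.70 log units; beyond the scatter) shows, so among these three compounds both sulfonyl groups read stronger than the carbamoyl, whichever aryl group they carry. No measurement at hand accounts for this shift.

Compound 3 changes the linking group and the aryl substituent together, so the share of each in the step stays unresolved. A (4-methoxyphenyl)carbamoyl or (4-fluorophenyl)sulfonyl group at this carbon would separate the two, and a simple amine or carboxylic acid here would show whether an aryl group is needed at all.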